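The source may report more compounds than this note shows. Statements on the series, on what has been measured and on what is new or still open speak of the compounds shown alone.

Measured so far in a functional assay on K562 cells for agonist activity at integrin alpha-M/beta-2 (Homo sapiens); a higher number here means that more compound is needed for the effect, a lower number that less compound is needed: compound 1 `CCOC(=O)CN1C(=O)S/C(=C\c2ccc(-c3ccc(Cl)cc3Cl)o2)C1=O` gives 13600 nM; compound 2 `CCOC(=O)CN1C(=O)S/C(=C\c2ccc(N3CCCC3)o2)C1=O` gives 23200 nM; compound 3 `CCOC(=O)CN1C(=O)S/C(=C\c2ccc(-c3ccc(C)cc3Br)o2)C1=O` gives 18600 nM.

Compound 1 shows the lowest of the three numbers, but its steps to the others, a 1.7-fold higher number from compound 1 to compound 2 (0.23 log units; within the scatter) and a 1.4-fold higher number from compound 1 to compound 3 (0.14 log units; within the scatter), both sit within the scatter, as does a 1.2-fold lower number from compound 2 to compound 3 (0.10 log units; within the scatter); the three compounds are not separable on these data. Compound 4 `CCCN1C(=O)S/C(=C\c2ccc(-c3ccc(Cl)cc3Cl)o2)C1=O` keeps the 2,4-dichlorophenyl of compound 1 and differs only at the chain: ethyl in place of ethoxycarbonyl on a saturated chain carbon bound to an amide-type nitrogen in a ring. Within the data shown here, none of the measured steps touches this chain; all three vary the group on the aromatic carbon, so no step among them bears directly on the change. Among the measured compounds shown here, with no precedent either way, the expected step of a 1.1-fold higher number from compound 1 to compound 4 (0.04 log units; within the scatter) is none beyond the scatter. Compound 4 is therefore estimated at 15000 nM, with a range of 5000 nM to 45000 nM.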

Compound 4, half-maximal effective concentration: "not active" (no number reported)
Nothing numeric was reported for compound 4, and the estimate cannot be compared.
By their numbers in this assay, from the lowest: compounds 1, 3 and 2 (each within the scatter of the next).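

Among these compounds, compound 4 is reported as "not active" in this assay with no number, so no step from compound 1 to compound 4 can be read. The compounds shown leave open whether propyl in place of (ethoxycarbonyl)methyl gives the same result with other aromatic groups. Nothing available explains this result.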